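Phenol methylation in a styryl butenolide series

This account rests on a few compounds, and the source may have more. Where it says the series, first, only, none or still open, it means among the compounds named here.

Four compounds of one series are considered. Compound 1 `COc1ccc(/C=C/C2(C)C=CC(=O)O2)c(OC)c1OC`, compound 2 `COc1c(O)ccc(/C=C/C2(C)C=CC(=O)O2)c1OC` and compound 3 `CC1(/C=C/c2ccc(O)cc2)C=CC(=O)O1` have been measured; compound 4 `COc1ccc(/C=C/C2(C)C=CC(=O)O2)cc1` has not. In a functional assay on HT-29 cells (Homo sapiens) for inhibition, read by sulforhodamine B assay, with a stated time of 48 h (a lower number here means a stronger inhibitor of growth, a higher number a weaker inhibitor of growth), compound 2 gives 19100 nM, compound 1 gives 133000 nM and compound 3 gives 122000 nM. The values of compound 3 and compound 1 lie within the usual scatter of each other, so no order is drawn between them; compound 2 stands apart from both.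

The change from compound 2 to compound 1 is methyl in place of hydrogen on an oxygen on an aromatic ring. It produced a 7.0-fold higher number from compound 2 to compound 1 (0.84 log units; beyond the scatter), a step beyond the scatter. Compound 4 differs from compound 3 by methyl in place of hydrogen on an oxygen on an aromatic ring, the same change at the same kind of place. The difference between the cores of compound 3 and compound 2 is not broken down here, so how closely the two steps correspond is open.

Going by the values given here, the single earlier step is the only guide. For compound 4 the expected step from compound 3 is a 4.5-fold higher number from compound 3 to compound 4 (0.65 log units; beyond the scatter), resting on the step seen from compound 2 to compound 1 of a 7.0-fold higher number from compound 2 to compound 1 (0.84 log units; beyond the scatter). With a single precedent and a different core, the range is kept wide. Compound 4 is estimated at 550000 nM, between 160000 nM and 1900000 nM, with a real chance that this assay reports only a limit rather than a number.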

Compound 4, concentration for total growth inhibition: 92900 nM
Compound 4: the middle estimate sits 5.9-fold (0.77 log units) above what was measured, and the stated range ends above it.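

In this assay the change from hydroxy to methoxy gives a 1.3-fold lower number from compound 3 to compound 4 (0.12 log units; within the scatter) and so does not separate these two compounds. On the evidence of these two pairs, the size of this change does not carry over from one core to the other, and the step seen on the core of compound 2 is no reliable guide to the step on the core of compound 3: the same change on two cores in this assay, a 7.0-fold higher number (0.84 log units; beyond the scatter) from compound 2 to compound 1 and a 1.3-fold lower number (0.12 log units; within the scatter) from compound 3 to compound 4, 9.1-fold (0.96 log units) apart, beyond the scatter of two such steps

Going by these compounds alone, each core contributes only one pair and the differences between the cores are not broken down, so these data do not show which part of a core governs the gap, whether either step is typical of its core, or what the step would be on a third core.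

The compounds shown leave open how a longer chain on the same oxygen, such as ethyl, would read on either core, and whether it would follow the methyl result on that core. Also open, from the compounds shown here alone, is how an amine or a carboxylic acid in place of the hydroxy would compare, which would test whether the contrast between the two cores extends beyond this single change.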